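Swapping Thiophenyl for Iodo on a Nucleoside Core

The compounds below may be only part of what the source reports. "The series", "measured", "known", "first", "only" and "open" are said of these compounds alone.

Compound 1 `Cc1nc(N)c2c(-c3cccs3)cn([C@@H]3O[C@H](CO)[C@@H](O)[C@H]3O)c2n1` was tested in a functional assay on K562 cells (Homo sapiens), read by MTT assay, with a stated time of 72 h; on this read-out lower numbers stand for stronger inhibition and higher numbers for weaker inhibition. In this assay compound 1 gives only a limit, > 20000 nM, so no number is known for it. A second compound, compound 2 `C#Cc1cn([C@@H]2O[C@H](CO)[C@@H](O)[C@H]2O)c2nc(N)nc(OC)c12`, was measured in the same way. In this assay compound 2 likewise gives only a limit, > 20000 nM. Going by the values given here, compound 1 therefore stands at the edge of what this assay can report, and the only evidence about it is the limit of > 20000 nM in this assay, at which 2 of the 2 values shown sit, with nothing that separates it from compound 2. Compound 3 `Cc1nc(N)c2c(I)cn([C@@H]3O[C@H](CO)[C@@H](O)[C@H]3O)c2n1` has not yet been measured. It differs from compound 1 in one place (iodo in place of thiophen-2-yl on an aromatic carbon); the thiophen-2-yl group leaves and an iodo group enters on the same aromatic carbon. No step between measured compounds exists to draw on, so the size of the change in this assay cannot be taken from anything shown. Given (the limit of > 20000 nM in this assay, at which 2 of the 2 values shown sit), the step expected a step that the limit leaves unreadable from compound 1 to compound 3 is none beyond the usual scatter, most likely ending again at a limit. Compound 3 is expected to give about 25000 nM, within a range from 5000 nM to 100000 nM.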

Compound 3, half-maximal inhibitory concentration: 1110 nM
For compound 3 the middle estimate is 23-fold (1.35 log units) above the measured one, outside the stated range (below it).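

In this assay the change on this aromatic carbon gives an at least 18-fold lower number from compound 1 to compound 3 (1.25 log units; beyond the scatter), which is large and beyond the usual scatter. This shows that the group on this carbon can decide whether the shared core registers on this read-out at all, something two limits alone could not reveal, and that a single iodo group can succeed here where the five-membered thiophen-2-yl ring does not. Compound 3 also gives the series its first real number, 1110 nM. Compound 1 and compound 2 still stand at a limit of the assay: the limit of > 20000 nM in this assay, at which 2 of the 3 values shown sit.

With only this one step, the compounds shown cannot tell whether the gain comes from losing the thiophen-2-yl ring or from gaining the iodo group, and they give no measured reason for it. Going by these compounds, it also remains open whether other groups on the same carbon, such as a bromo group, an amine or a carboxylic acid, would give a value like that of compound 3 or return to a limit.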